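The source may hold more compounds than are shown below. What is called first, only, known or untested is meant among the compounds shown, and "the series" means these compounds.

Measured compounds, inhibition of topoisomerase at one concentration:

compound 1 `Oc1cccc(-c2cc(-c3ccsc3)cc(-c3ccccc3O)n2)c1`: 10.2%
compound 2 `Oc1ccc(-c2cc(-c3ccsc3)cc(-c3cccc(O)c3)n2)cc1`: 17.1%

In an assay on isolated protein for inhibition of DNA topoisomerase 1 (Homo sapiens), with a stated time of 30 min, tested at 100 uM (on this read-out lower numbers stand for a weaker effect and higher numbers for a stronger effect at the one concentration tested), compound 1 gives the smaller of the two numbers shown, but its gap to compound 2, a number 6.9 percentage points higher from compound 1 to compound 2 (within the scatter), is within the scatter, so the two are not separated on this read-out.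

Compound 3 `Oc1cccc(-c2cc(-c3cccnc3)cc(-c3ccccc3O)n2)c1` differs from compound 1 in one place: pyridin-3-yl in place of thiophen-3-yl on an aromatic carbon. Within the data shown here, no measured step touches this position; the only step at hand, a number 6.9 percentage points higher from compound 1 to compound 2 (within the scatter), concerns a hydroxyphenyl group and changed nothing beyond the scatter. Among the measured compounds shown here, both measured compounds sit low on this assay, and the single exchange of one small aromatic ring for another gives no ground, on these two values alone, to expect a departure from that level. The step of a number 1.8 percentage points higher from compound 1 to compound 3 (within the scatter) is therefore expected to lie within the scatter.

Compound 3 is estimated at 12% in this assay, with a range from 0% to 28%.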

Compound 3, a percentage reported as inhibition, at one concentration (the size of the read-out at that concentration, not a potency): 1.9%
Estimate against measurement, compound 3: 10.1 percentage points above, within the range that was stated.
By their numbers in this assay, from the lowest: compounds 3, 1 and 2 (each within the scatter of the next, the first and the last beyond it).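

This position, opposite the ring nitrogen, now has its first measured exchange. In this assay, pyridin-3-yl in place of thiophen-3-yl gives a number 8.3 percentage points lower from compound 1 to compound 3 (within the scatter), so going from a five-membered to a six-membered aromatic ring with 1 hetero atom does not separate the pair on this read-out. Nothing at hand bears on what lies behind this outcome.

From the compounds shown here alone, it remains open whether a group of another kind at this carbon, such as an aminomethyl group, a carboxylic acid or a longer alkyl chain, would move the number beyond the scatter from compound 1. Going by these compounds, it is equally open whether the exchange would give the same result with the hydroxyphenyl groups of compound 2 in place.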